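Mirror-image cyclopropane configuration in an adenosine A3 series

The source may hold more compounds than are shown below. What is called first, only, known or untested is meant among the compounds shown, and "the series" means these compounds.

This account concerns a small set of compounds examined in an assay on isolated protein for binding affinity to adenosine receptor A3 (Homo sapiens); on this read-out lower numbers stand for stronger inhibition and higher numbers for weaker inhibition. Compound 1 `CNC(=O)[C@]12C[C@@H]1[C@@H](n1cnc3c(N[C@H]4C[C@@H]4c4ccc(F)c(F)c4)nc(C#Cc4cccc(F)c4)nc31)[C@H](O)[C@@H]2O` is measured there only as a limit, giving >= 99 nM. Compound 2 `CNC(=O)[C@]12C[C@@H]1[C@@H](n1cnc3c(NCc4cccc(Cl)c4)nc(C#Cc4ccc(Cl)s4)nc31)[C@H](O)[C@@H]2O` likewise stands at a limit in this assay, with >= 99 nM. Compound 3 `[N-]=[N+]=Nc1ccc(CNc2nc(C#Cc3ccc(F)c(F)c3)nc3c2ncn3[C@H]2[C@H](O)[C@H](O)[C@]3(CO)C[C@H]23)cc1` also reaches only a limit in this assay, with >= 99 nM. For the measured compounds named here, the picture across the measured compounds is therefore uniform: the limit of >= 99 nM in this assay, at which 3 of the 3 values shown sit, so none of them is set apart from the others by a number, and no step between two measured values can be read from these data.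

Compound 4 `CNC(=O)[C@]12C[C@@H]1[C@@H](n1cnc3c(N[C@@H]4C[C@H]4c4ccc(F)c(F)c4)nc(C#Cc4cccc(F)c4)nc31)[C@H](O)[C@@H]2O` has not yet been measured in this assay. Its relation to compound 1 is a change of configuration alone: the two compounds have the same atoms and bonds and differ only in configuration as drawn: 2 of 7 stereo elements differ; a stereocentre at a saturated ring carbon is drawn S in compound 1 and R in compound 4; a stereocentre at a saturated ring carbon is drawn R in compound 1 and S in compound 4. Going by the values given here, no measured step of this kind is available, and compound 1 itself shows only a limit, so there is no footing for expecting a shift in either direction beyond the usual scatter. The step that the limit leaves unreadable from compound 1 to compound 4 is accordingly expected to be small. Compound 4 is estimated at 300 nM, within a range from 50 nM to 3000 nM, with a fair chance that this assay again reports only a limit.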

Compound 4, inhibition constant: >= 99 nM
Compound 4 ended at the assay's limit; the forecaster's own chance of this, stated with the estimate: 75%; the middle value lies beyond the limit too.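

No new step can be read: compound 1 and compound 4 both end at a limit in this assay, so the change of configuration between them has no readable size: the limit of >= 99 nM in this assay, at which 4 of the 4 values shown sit. The compounds shown leave open whether that change of configuration shifts the read-out at all, and how far any compound lies beyond the limit.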